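From 4-methoxybenzyl to 4-nitrophenyl at the solubility limit

This account rests on a few compounds, and the source may have more. Where it says the series, first, only, none or still open, it means among the compounds named here.

Compound 3 (`COc1ccc(Cn2cc(CO[C@H]3O[C@H](CO)[C@@H](O)[C@H](O)[C@@H]3O)nn2)cc1`) carries a 4-methoxybenzyl group on an aromatic nitrogen of the shared core. In a physicochemical assay for solubility, read by LC-MS, using the shake flask method, measured as thermodynamic solubility, with a stated time of 24 h, at pH 6.5 (on this read-out higher numbers stand for higher solubility and lower numbers for lower solubility), compound 3 gives > 3000 ug/mL as its reading, and this is a limit and not a number. In this assay compound 1 (`O=C(O)c1ccc(-n2cc(CO[C@H]3O[C@H](CO)[C@@H](O)[C@H](O)[C@@H]3O)nn2)cc1`) gives > 3000 ug/mL as its reading, again a limit. In this assay compound 2 (`O=C(O)c1cncc(-n2cc(CO[C@H]3O[C@H](CO)[C@@H](O)[C@H](O)[C@@H]3O)nn2)c1`) gives > 3000 ug/mL as its reading, a limit as well. The three measured compounds thus stand together at the limit of > 3000 ug/mL in this assay, at which 3 of the 3 values shown sit, and compound 3 has no readable rank among them.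

The next structure, compound 4 (`O=[N+]([O-])c1ccc(-n2cc(CO[C@H]3O[C@H](CO)[C@@H](O)[C@H](O)[C@@H]3O)nn2)cc1`), has 4-nitrophenyl in place of 4-methoxybenzyl on that aromatic nitrogen (4-nitrophenyl in place of 4-methoxybenzyl on an aromatic nitrogen). Two measured steps also change the group on this nitrogen, yet neither a step that the two limits leave unreadable from compound 1 to compound 3 nor a step that the two limits leave unreadable from compound 2 to compound 3 gives a size to carry over. With no measured size to draw on, no step beyond the usual scatter is expected in this assay and any small movement is expected to be downward. The expected step is an at least 1.2-fold lower number from compound 3 to compound 4 (0.07 log units; that floor lies within the scatter) as far as a limit allows it to be stated. For compound 4 the estimate is 2500 ug/mL with an expected range from 800 ug/mL to 6000 ug/mL in this reading.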

Compound 4, solubility: 2600 ug/mL
Compound 4: the middle estimate sits 1.0-fold (0.02 log units) below what was measured, within the range that was stated.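

In this assay, compound 4 is the first compound shown whose reading is a number and not a limit, so a change of the group on this aromatic nitrogen can at last be given a floor: an at least 1.1-fold lower number from compound 3 to compound 4 (0.06 log units; that floor lies within the scatter), an at least 1.1-fold lower number from compound 2 to compound 4 (0.06 log units; that floor lies within the scatter) and an at least 1.1-fold lower number from compound 1 to compound 4 (0.06 log units; that floor lies within the scatter). These three steps are floors only, each lying within the scatter, so they fix no true size for the change, whether the group that leaves is 4-methoxybenzyl, 5-carboxypyridin-3-yl or 4-carboxyphenyl. Compound 4 is also the only one of the four compounds whose reading does not stand at the limit: the limit of > 3000 ug/mL in this assay, at which 3 of the 4 values shown sit.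

On these data alone, the steps among compounds 1, 2 and 3 cannot be read, and how far any of those three lies from compound 4 stays open beyond these floors. Also open, as far as these compounds go, is whether an amine or a nitrile in place of the nitro of 4-nitrophenyl, or a longer chain between that aromatic ring and the aromatic nitrogen, would give a number or a limit in this assay.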